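Cyclohexyl for pentyl on the amide of compound 2

A few compounds are considered here, and "the series" means these few. Any claim that something is new, unique, unknown or untested is made for them only; others in the source may bear on it.

Compound 1, `C=CC1=C(C(=O)Nc2ccccc2OC)C(c2ccc(F)cc2)OC1`: in a functional assay on SW480 cells (Homo sapiens) for cytotoxicity, read by MTT assay, with a stated time of 24 h (a higher number here means a weaker inhibitor, a lower number a stronger inhibitor), compound 1 gives > 100000 nM, which is a limit of the assay and not a number.
Compound 2, `C=CC1=C(C(=O)NCCCCC)C(c2ccc(F)cc2)OC1`: in this assay compound 2 gives > 100000 nM, again a limit of the assay and not a number.

The two measured compounds share one core and differ only in the group on the amide-type nitrogen. The step between them, a step that the two limits leave unreadable from compound 1 to compound 2, cannot be read, since both values sit on (the limit of > 100000 nM in this assay, at which 2 of the 2 values shown sit). Compound 2 thus stands at the limit of the assay, with no number of its own and no measured neighbour that gives one.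

Compound 3, `C=CC1=C(C(=O)NC2CCCCC2)C(c2ccc(F)cc2)OC1`, differs from compound 2 by cyclohexyl in place of pentyl on an amide-type nitrogen. Within the data shown here, only the step from compound 1 to compound 2 touches this position, and its size is not readable, so there is no measured step to carry over. With both measured compounds at the limit, compound 3 is expected to remain there as well. The expected step is a step that the limit leaves unreadable from compound 2 to compound 3, none beyond the scatter. Compound 3 is therefore estimated at 150000 nM, with a range from 50000 nM to 500000 nM.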

Compound 3, half-maximal inhibitory concentration: > 100000 nM
Compound 3 gave a limit, no number; the forecaster's own chance of this, stated with the estimate: 85%; the middle value lies beyond the limit too.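

The steps from compound 1 to compound 3 and from compound 2 to compound 3 cannot be read, since all three compounds sit at one limit of the assay, which is no number: the limit of > 100000 nM in this assay, at which 3 of the 3 values shown sit.

The compounds shown leave open whether any group on the amide-type nitrogen of the shared core gives a readable value in this assay and how such groups would compare.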